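The source may hold more compounds than are shown below. What is called first, only, known or untested is meant among the compounds shown, and "the series" means these compounds.

Working notes on the series. Three compounds have been run in a functional assay on HEK293 cells for agonist activity at Glucose-dependent insulinotropic receptor (Homo sapiens), read by cAMP accumulation, with a stated time of 60 min; a higher number here means a larger maximal response, a lower number a smaller maximal response. Compound 1 `COc1cc2nc(N3CCC4CCC(C3)N4C(=O)OC(C)(C)C)nc(Nc3ccc(S(C)(=O)=O)cc3F)c2cc1OC` gives 56.9%. Compound 2 `COc1cc2nc(OC3CCN(C(=O)OC(C)(C)C)CC3)nc(Nc3ccc(S(C)(=O)=O)cc3F)c2cc1OC` gives 19.6% in this assay, and compound 3 `COc1cc2nc(OC3CCN(C(=O)OC(C)(C)C)CC3)nc(Nc3ccc(S(C)(=O)=O)cc3)c2cc1OC` gives 17.9%. The difference between the core of compound 1 and the core of compound 2 is not broken down here; compound 1 stands highest of the three, and its gap to each of the other two lies beyond the scatter. Compound 2 and compound 3 differ in one place only: hydrogen in place of fluoro on an aromatic carbon. The measured step is a number 1.7 percentage points lower from compound 2 to compound 3 (within the scatter), so the maximal response is left essentially where it was.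

Compound 4 `COc1cc2nc(N3CCC4CCC(C3)N4C(=O)OC(C)(C)C)nc(Nc3ccc(S(C)(=O)=O)cc3)c2cc1OC` has not yet been measured in this assay. It is related to compound 1 by the same change, (hydrogen in place of fluoro on an aromatic carbon), with the same surroundings as in the pair of compound 2 and compound 3. Among the compounds with values here, for compound 4 the expected step is a number 1.9 percentage points lower from compound 1 to compound 4 (within the scatter), of about the size of the earlier one, because a number 1.7 percentage points lower from compound 2 to compound 3 (within the scatter), and that pair is the only measured instance of this change, so the expectation rests on it alone. For compound 4 the estimated maximal response in this assay is 55%, with a range from 42% to 68%.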

Compound 4, largest response reached (Emax), in percent of the reference or control that the assay uses: 32.7%
Compound 4: middle estimate off by 22.3 percentage points, on the high side; measured number outside the range, below it.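

In this assay, hydrogen in place of fluoro on an aromatic carbon is not a step of fixed size in this series, since on the core of compound 1 it reads a number 24.2 percentage points lower from compound 1 to compound 4 (beyond the scatter), and the two instances of the change disagree: the same change on two cores in this assay, a number 1.7 percentage points lower (within the scatter) from compound 2 to compound 3 and a number 24.2 percentage points lower (beyond the scatter) from compound 1 to compound 4, 22.5 percentage points apart, beyond the scatter of two such steps A step read on one core therefore cannot simply be carried to the other here, and the small step on the core of compound 2 gave no safe guide to the core of compound 1. What this does not show is which part of the cores sets the size of the step, as they differ in more than one place and only two pairs are available, so no rule follows for any further core, and nothing is shown about why the fluoro counts on one core and not measurably on the other.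

The compounds shown leave open whether chloro or methyl at the place of the fluoro would keep the response of compound 1 on its core. They also leave open whether the step from fluoro to hydrogen would stay the same size with a free amine or an acetyl group in place of the tert-butyl carbamate.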